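The compounds below may be only part of what the source reports. "The series", "measured", "known", "first", "only" and "open" are said of these compounds alone.

Of the compounds shown here, three have numbers so far in an assay on microsomes from liver with sterol O-acyltransferase 1 (Rattus norvegicus) as the target; on this read-out lower numbers stand for stronger inhibition and higher numbers for weaker inhibition. Compound 1 `CCN(CC)CCN(CCCCCSc1nc(-c2ccccc2)c(-c2ccccc2)[nH]1)C(=O)NC(C)C` gives 660 nM, the highest of the three. Compound 2 `COCCOCCN(CCCCCSc1nc(-c2ccc(OC)cc2)c(-c2ccc(OC)cc2)[nH]1)C(=O)NC(C)C` gives 500 nM, which lies within the scatter of compound 1. Compound 3 `CCCCCCCN(CCCCCSc1nc(C2CCCCC2)c(C2CCCCC2)[nH]1)C(=O)Nc1ccc(F)cc1F` gives 20 nM, a number well beyond the scatter from compound 1. Compound 4 `CCCCOCCN(CCCCCSc1nc(-c2ccccc2)c(-c2ccccc2)[nH]1)C(=O)NC(C)C` has not yet been measured; it differs from compound 1 in one place: butoxy in place of diethylamino on a saturated chain carbon, two bonds along the chain from an amide-type nitrogen. Among the measured compounds shown here, no measured pair shows this change on its own, so there is no step to lean on. Compound 2 carries an ether chain in the same region, yet it also differs elsewhere, so its number cannot be tied to this change. For compound 4 a step of a 1.5-fold lower number from compound 1 to compound 4 (0.17 log units; within the scatter) is expected, within the scatter. Compound 4 is estimated at 450 nM, between 150 nM and 1400 nM.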

Compound 4, half-maximal inhibitory concentration: 190 nM
The estimate for compound 4 lay 2.4-fold (0.37 log units) above the measured number; the measured number falls inside the stated range.
By their numbers in this assay, from the lowest: compound 3; then compound 4; then compounds 2 and 1 (each within the scatter of the next).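

At this position on the chain, the group matters: butoxy in place of diethylamino gives a 3.5-fold lower number from compound 1 to compound 4 (0.54 log units; beyond the scatter) in this assay. The two groups have the same counts of heavy atoms, hydrogen-bond donors and acceptors, so those counts alone do not set the number here. No measurement at hand explains the step.

The compounds shown cannot separate the swap of nitrogen for oxygen from the change in chain shape. A dipropylamino group or a simple hexyl chain at this place would help tell these apart.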